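The source may report more compounds than this note shows. Statements on the series, on what has been measured and on what is new or still open speak of the compounds shown alone.

Series notes. Compound 1 `C/C(CN(C[C@H]1Cc2ccccc2CN1)[C@H]1CCCc2cccnc21)=C(/F)CN` carries a 4-amino-3-fluoro-2-methylbut-2-en-1-yl group on the amine nitrogen of the shared core. For the measured compounds named here, in a functional assay on CCRF-CEM cells for antagonist activity at C-X-C chemokine receptor type 4 (Homo sapiens), read by calcium flux, with stated times of 25 min and 90 s (on this read-out higher numbers stand for weaker inhibition and lower numbers for stronger inhibition), compound 1 gives 1800 nM, the highest of the two numbers so far. Its nearest neighbour is compound 2 `C/C(=C/CN)CN(C[C@H]1Cc2ccccc2CN1)[C@H]1CCCc2cccnc21`, which in this assay gives 28 nM; the step of a 64-fold lower number from compound 1 to compound 2 (1.81 log units; beyond the scatter) is large and rests on a single exchange at a saturated chain carbon bound to an amine nitrogen, the fluorine leaving.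

Compound 3 `N[C@H]1CC[C@@H](N(C[C@H]2Cc3ccccc3CN2)[C@H]2CCCc3cccnc32)CC1` has not been measured in this assay. Relative to compound 1 the change is 4-aminocyclohexyl in place of 4-amino-3-fluoro-2-methylbut-2-en-1-yl on an amine nitrogen. Going by the values given here, the only step that bears on it is a 64-fold lower number from compound 1 to compound 2 (1.81 log units; beyond the scatter), in which loss of the fluorine alone moved the number by a large amount downward. Among the compounds with values here, the change to compound 3 also removes that fluorine, together with the double bond, while no measured step covers the ring closure itself. On these data alone, a step in the same direction is therefore expected for compound 3, about a 30-fold lower number from compound 1 to compound 3 (1.48 log units; beyond the scatter), with a wide range since the cyclohexyl is untested. Compound 3 is expected to give about 60 nM in this assay, between 10 nM and 400 nM.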

Compound 3, half-maximal inhibitory concentration: 1800 nM
Beside the measured number, compound 3's estimate is 30-fold (1.48 log units) below it; the measured number lies above the stated range.
By their numbers in this assay, from the lowest: compound 2; then compounds 1 and 3 (each within the scatter of the next).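

In this assay, the absence of the fluorine does not by itself set the number on this amine nitrogen: 4-aminocyclohexyl also carries no fluorine, yet the record shows no change at the digits printed from compound 1 to compound 3 (within the scatter), so the fluorinated open chain and the ring cannot be told apart here. Against the open chain without fluorine, the same ring gives a 64-fold higher number from compound 2 to compound 3 (1.81 log units; beyond the scatter), a step as large as the one seen on losing the fluorine, so a group of similar size with a terminal amine is not enough to hold the low number. Among the three groups shown, that low number goes only with the unfluorinated open chain, and nothing available accounts for the loss on going to the ring.

The change to 4-aminocyclohexyl removes the open chain and its double bond and adds two defined stereocentres in one exchange, so the part played by each stays unresolved. A saturated 4-aminobutyl chain, the other stereoisomer of 4-aminocyclohexyl, or a piperidine ring on this nitrogen would separate the ring from the loss of the double bond.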